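The source may report more compounds than this note shows. Statements on the series, on what has been measured and on what is new or still open speak of the compounds shown alone.

Measured so far in a physicochemical assay for solubility, read by turbidimetry, measured as kinetic solubility, at pH 7.4; a higher number here means a more soluble compound, a lower number a less soluble compound:
- compound 1 `O=C(NCCCCc1ccccc1)c1cccc(C2SCC(=O)N2c2cccc(-c3c[nH]nn3)c2)c1`: 20000 nM
- compound 2 `O=C(NCCCCc1ccccc1)c1cccc(C2SCC(=O)N2c2cccc(F)c2)c1`: 10000 nM

Compound 2 stands within the scatter of compound 1, so neither compound sets a clear high or low mark. Next is compound 3 `O=C(NCCCCc1ccccc1)c1cccc(C2SCC(=O)N2c2ccccc2F)c1`, with 2-fluorophenyl in place of 3-fluorophenyl on an amide-type nitrogen in a ring. Going by the values given here, the only measured step, a 2.0-fold lower number from compound 1 to compound 2 (0.30 log units; within the scatter), replaces 1H-1,2,3-triazol-4-yl with fluoro on an aromatic carbon. Among the compounds with values here, it bears on the new change only indirectly, since no measured pair moves the fluorine. Given that small step from compound 1 to compound 2, no shift beyond the scatter is expected in this assay, and no direction is favoured. The expected change is no change at the digits printed from compound 2 to compound 3 (within the scatter). For compound 3 the estimated value is 10000 nM, with an expected range of 4000 nM to 25000 nM.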

Compound 3, solubility: 10000 nM
Compound 3: the middle estimate sits on the measured number at the digits printed, and the stated range covers the measured number.
By their numbers in this assay, from the lowest: compounds 2, 3 and 1 (each within the scatter of the next).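

In this assay, going by these compounds alone, 2-fluorophenyl in place of 3-fluorophenyl on an amide-type nitrogen in a ring gives no change at the digits printed from compound 2 to compound 3 (within the scatter), the first measured pair in which only the place of the fluorine differs. The larger exchange at that nitrogen, a fluorophenyl group for the triazole-bearing phenyl group, reads as a 2.0-fold lower number from compound 1 to compound 3 (0.30 log units; within the scatter), so compounds 1, 2 and 3 all stand within the scatter of one another. No measured evidence is available to account for this result.

The compounds shown leave open whether this position stays as flat with a carboxylic acid or a tertiary amine on the aromatic ring in place of the fluorine. On these data alone, all three also share the same core and the same amide chain, so the effect of a shorter or longer chain remains unknown.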